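The source may report more compounds than this note shows. Statements on the series, on what has been measured and on what is new or still open speak of the compounds shown alone.

Measured compounds in a functional assay on cells (Melanoma cell, Homo sapiens) for inhibition; on this read-out lower numbers stand for stronger inhibition of growth and higher numbers for weaker inhibition of growth:
- compound 1 `COc1ccc(-c2nc3sc(Cc4ccccc4)nn3c2SC#N)cc1` gives 77600 nM
- compound 2 `O=Cc1c(-c2ccc(Br)cc2)nc2sc(Cc3ccccc3)nn12` gives 19500 nM
- compound 3 `O=Cc1c(-c2ccc([N+](=O)[O-])cc2)nc2sc(Cc3ccccc3)nn12` gives 42700 nM

Among these three, compound 1 has the highest number. Its gap to compound 3 is within the scatter, so the two cannot be ordered, while compound 2 sits beyond the scatter below it. Going by the values given here, the only change measured here on a single site is a 2.2-fold higher number from compound 2 to compound 3 (0.34 log units; beyond the scatter), a swap of one substituent for another on the aryl ring of the shared core.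

Compound 4 `N#CSc1c(-c2ccccc2)nc2sc(Cc3ccccc3)nn12` differs from compound 1 by hydrogen in place of methoxy on an aromatic carbon. Among the compounds with values here, no measured pair shows a group being removed from that ring, and the step between compound 2 and compound 3 concerns two groups that are absent from compound 1, so it bears on the change only in showing that substituents on this ring shift the number modestly. With no closer guide, a step of no more than the scatter in this assay is expected, so the number for compound 4 is estimated at 70000 nM, within 25000 nM to 200000 nM, which would mean a 1.1-fold lower number from compound 1 to compound 4 (0.04 log units; within the scatter).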

Compound 4, concentration for total growth inhibition: 85100 nM
Estimate against measurement, compound 4: 1.2-fold (0.08 log units) below; low and high end bracket the measured number.
By their numbers in this assay, from the lowest: compound 2; then compounds 3, 1 and 4 (each within the scatter of the next).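

In this assay, going from 4-methoxyphenyl to phenyl gives a 1.1-fold higher number from compound 1 to compound 4 (0.04 log units; within the scatter), so removing the methoxy group leaves no change that can be told apart from the scatter. Going by these compounds alone, this is the first direct reading of a group being removed from this ring, as the earlier step only compared two other substituents on a compound with a different group elsewhere on the shared core. With this core, the methoxy group is therefore not required for the activity seen in this assay. No supporting measurement is available to explain this result.

On these data alone, whether other groups at this place, such as an amine or a carboxylic acid, would shift the number remains open. Also open, as far as these compounds go, is whether hydrogen and methoxy would compare the same way of compound 2 and compound 3.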